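The compounds below may be only part of what the source reports. "The series", "measured", "known", "first", "only" and "open" are said of these compounds alone.

The measured compounds in a functional assay on L1210 cells (Mus musculus) for antiproliferative activity (on this read-out lower numbers stand for lower potency and higher numbers for higher potency (the scale is a negative logarithm)), are three:

Compound 1, `CN(C)/N=N/c1ccc(S(=O)(=O)Nc2ncccn2)cc1`, with 3.74.
Compound 2, `CN(Cc1ccccc1)/N=N/c1nc[nH]c1C(N)=O`, with 3.43.
Compound 3, `CN(C)/N=N/c1c(F)cccc1F`, with 3.63.

Among these numbers compound 2 stands lowest. Its nearest neighbour is compound 3, whose value lies within the usual scatter of compound 2, so the two cannot be told apart on this read-out. Compound 1 lies furthest from compound 2, and that gap is beyond the scatter, so compound 1 gives a higher number in this assay than compound 2 does. Among the compounds with values here, all three share a dimethyl- or alkyl-substituted triazene arm, yet they carry unrelated cores, and no pair among them differs in only one place.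

Within the data shown here, compound 4, `CCCN(C)/N=N/c1nc[nH]c1C(N)=O`, is the one compound not yet measured. Compared with compound 2 the change is ethyl in place of phenyl on a saturated chain carbon bound to an amine nitrogen. Among the measured compounds shown here, nothing among the measured compounds shows what such a swap on this core does, so no step of any size is established. The expectation is that the step of a number 0.07 log units higher from compound 2 to compound 4 (within the scatter) from compound 2 to compound 4 is small and not beyond the scatter in either direction. Compound 4 is therefore estimated at 3.5, with a range from 3.1 to 3.9.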

Compound 4, logarithm of the reciprocal of the active concentration, log(1/C): 3.58
Estimate against measurement, compound 4: 0.08 log units below; the range from low to high includes it.
By their numbers in this assay, from the lowest: compounds 2, 4, 3 and 1 (each within the scatter of the next, the first and the last beyond it).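

In this assay, ethyl in place of phenyl on a saturated chain carbon bound to an amine nitrogen gives a number 0.15 log units higher from compound 2 to compound 4 (within the scatter), so compound 2 and compound 4 cannot be told apart on this read-out. Within the data shown here, this is the first step read on this core, and it shows that this place can lose the six-membered aromatic ring of carbon only, with 6 heavy atoms leaving and 2 entering, without any change that stands out from the scatter. No accompanying measurement bears on this result, so the data give no explanation for it.

From the compounds shown here alone, a single step sets no trend, so it remains open whether a longer chain, a carboxylic acid or an amine at this place would also stay within the scatter of compound 2. Among these compounds, it is also open whether the same swap would give a similarly small step on another core, as the cores of compound 1 and compound 3 offer no pair that differs in only one place.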